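Removing the benzyl group from compound 3

The source may hold more compounds than are shown below. What is called first, only, known or untested is meant among the compounds shown, and "the series" means these compounds.

Going by the values given here, in an ADME assay on CHO cells (Cricetulus griseus) for inhibition, read by MTT assay (on this read-out higher numbers stand for weaker inhibition and lower numbers for stronger inhibition), compound 3 `CCN(CC)Cc1ccc(C)c(Nc2nc3ccccc3n2Cc2ccc(C(F)(F)F)cc2)c1O` gives 33900 nM, the only true number in this small set. Compound 1 `CCN(CC)Cc1cccc(Nc2nc3ccccc3[nH]2)c1O` gives > 50000 nM, which is a limit of the assay. Compound 2 `CCN(CC)Cc1ccc(C)c(Nc2nc3ccccc3n2Cc2ccc(F)cc2)c1O` gives > 50000 nM, which is also a limit. The remaining data point is the limit of > 50000 nM in this assay, at which 2 of the 3 values shown sit.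

Compound 4 `CCN(CC)Cc1ccc(C)c(Nc2nc3ccccc3[nH]2)c1O` follows from compound 3 by one change: hydrogen in place of 4-(trifluoromethyl)benzyl on an aromatic nitrogen.

Among the compounds with values here, the one measured step is an at least 1.4-fold lower number from compound 2 to compound 3 (0.16 log units; that floor lies within the scatter). It alters the benzyl group but does not remove it, so it bears on this change only loosely. Compound 1 also has hydrogen on that aromatic nitrogen, and its entry remains the limit > 50000 nM.

In this assay a step towards a higher number is therefore expected, though none clearly beyond the scatter. The expected step is a 1.8-fold higher number from compound 3 to compound 4 (0.25 log units; within the scatter). Compound 4 is estimated at 60000 nM, with an expected range of 30000 nM to 120000 nM, and it may well be reported only as a limit.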

Compound 4, half-maximal inhibitory concentration: > 50000 nM
Compound 4 ended at the assay's limit; the forecaster's own chance of this, stated with the estimate: 75%; the middle value lies beyond the limit too.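

In this assay, hydrogen in place of 4-(trifluoromethyl)benzyl on the aromatic nitrogen gives an at least 1.4-fold higher number from compound 3 to compound 4 (0.16 log units; that floor lies within the scatter), so the change cannot yet be separated from the scatter. Hydrogen on this nitrogen now leaves both compound 1 and its methyl-bearing counterpart compound 4 at the limit, as compound 2 with 4-fluorobenzyl is too, and compound 3 alone gives a true number: the limit of > 50000 nM in this assay, at which 3 of the 4 values shown sit. The steps from compound 2 and from compound 1 to compound 4 cannot be read, as both ends of each are limits.

As far as these compounds go, how far compound 4 truly lies from compound 3 stays open, and with it whether 4-(trifluoromethyl)benzyl contributes to inhibition at all. Also open, from the compounds shown here alone, is how this nitrogen behaves with a methyl, a longer alkyl chain or a benzyl bearing a carboxylic acid.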